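This account rests on a few compounds, and the source may have more. Where it says the series, first, only, none or still open, it means among the compounds named here.

Of the compounds shown here, two of a shared core have been measured in an ADME assay on microsomes from liver (Homo sapiens) for metabolic stability, tested at 2.5 uM; on this read-out lower numbers stand for slow clearance and higher numbers for fast clearance. Compound 1 `Cc1ccc(S(=O)(=O)c2cnc3cc(F)ccc3c2-c2cccc(F)c2)cc1F` gives 0.41 mL/min in this assay, while compound 2 `Cc1ccc(S(=O)(=O)c2cnc3cc(F)ccc3c2-c2ccc(Cl)cc2)cc1C` gives 7.88 mL/min. Compound 2 thus stands at the higher of the two numbers, and its gap to compound 1 lies beyond the usual scatter. Compound 2 differs from compound 1 in two places at once, so neither change alone can be tied to that gap.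

Compound 3 `Cc1ccc(S(=O)(=O)c2cnc3cc(F)ccc3c2-c2cccc(F)c2)cc1C` has not yet been measured in this assay. It differs from compound 2 in one place: 3-fluorophenyl in place of 4-chlorophenyl on an aromatic carbon. This change carries compound 3 halfway toward compound 1. Compound 3 is expected to fall between the two measured values, with a step of a 2.6-fold lower number from compound 2 to compound 3 (0.42 log units; beyond the scatter) anticipated. Compound 3 is therefore estimated at 3 mL/min in this assay, within a range from 0.9 mL/min to 9.5 mL/min, an expectation that rests only on compound 1 and compound 2.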

Compound 3, intrinsic clearance in a liver preparation (reported as CLH), per the amount of preparation that the assay uses: 3.71 mL/min
Beside the measured number, compound 3's estimate is 1.2-fold (0.09 log units) below it; the range from low to high includes it.
By their numbers in this assay, from the lowest: compound 1; then compound 3; then compound 2.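

Read one place at a time, the gap that compound 1 and compound 2 left unassigned now splits into two single changes, and both register in this assay. Putting 3-fluorophenyl in place of 4-chlorophenyl on the aromatic carbon gives a 2.1-fold lower number from compound 2 to compound 3 (0.33 log units; beyond the scatter) while methyl in place of fluoro on an aromatic carbon gives a 9.0-fold higher number from compound 1 to compound 3 (0.96 log units; beyond the scatter) and so holds the larger share of that gap by its printed size. Nothing measured here says why either change acts as it does.

The swap at this place alters both the halogen and where it sits on the phenyl, so the compounds shown leave open which of the two carries the step, and 3-chlorophenyl or 4-fluorophenyl would separate them. Also open, as far as these compounds go, is whether an unsubstituted phenyl or a 3-methoxyphenyl here would land nearer compound 1 or compound 2.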